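The compounds below may be only part of what the source reports. "The series", "measured", "known", "first", "only" and "open" are said of these compounds alone.

Two compounds built on the same core frame this step, and both were tested in an ADME assay on L02 cells (Homo sapiens) for cytotoxicity, read by MTT assay, with a stated time of 24 h; on this read-out lower numbers stand for stronger inhibition and higher numbers for weaker inhibition. In that test, compound 1 `CN1C/C(=C\c2cccnc2)C(=O)/C(=C/c2ccccc2F)C1` gives 15900 nM. Compound 2 `O=C1/C(=C/c2cccnc2)CN(S(=O)(=O)c2ccc([N+](=O)[O-])cc2)C/C1=C\c1ccccc1F` gives only a limit, > 20000 nM, and not a number. Its position is thus (the limit of > 20000 nM in this assay, at which 1 of the 2 values shown sits).

Compound 3 `O=C1/C(=C/c2cccnc2)CN(S(=O)(=O)c2ccc(Br)cc2)C/C1=C\c1ccccc1F` has not yet been measured. It differs from compound 2 in a single place, (bromo in place of nitro on an aromatic carbon), with bromo in place of nitro on an aromatic carbon, para to a large group. Going by the values given here, no pair of measured compounds shows what such a change does, so any forecast for this assay has little to rest on. Among the compounds with values here, the one firm number comes from compound 1 at 15900 nM, and it offers a rough anchor for the expectation. The expected at least 1.1-fold lower number from compound 2 to compound 3 (0.04 log units; that floor lies within the scatter) is no step beyond the usual scatter, with neither direction favoured. Another reading that returns only a limit would therefore be no surprise. For compound 3 the expected value is 18000 nM, with an estimated range from 8000 nM to 32000 nM.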

Compound 3, half-maximal inhibitory concentration: 14600 nM
Estimate against measurement, compound 3: 1.2-fold (0.09 log units) above; low and high end bracket the measured number.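

Compound 2 stands only at a limit and not at a number: the limit of > 20000 nM in this assay, at which 1 of the 3 values shown sits. Bromo in place of nitro gives an at least 1.3-fold lower number from compound 2 to compound 3 (0.13 log units; that floor lies within the scatter), so the aromatic carbon on the sulfonyl side of the shared core now carries a group with a true number in this assay, although the floor of that step lies within the usual scatter. (4-Bromophenyl)sulfonyl in place of methyl on the ring nitrogen gives a 1.1-fold lower number from compound 1 to compound 3 (0.04 log units; within the scatter), which shows that this exchange on the nitrogen, unreadable from the limit of compound 2 alone, makes no difference beyond the scatter in this assay.

The compounds shown leave open how an amine or a carboxylic acid on that same aromatic carbon would read, and whether a longer chain in place of methyl on the ring nitrogen would stay level with compound 1 and compound 3. They also leave open how far the true value of compound 2 lies from that of compound 3, as only a limit stands for compound 2.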